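Swapping the aryl group on the triazole of a spiro core

This account rests on a few compounds, and the source may have more. Where it says the series, first, only, none or still open, it means among the compounds named here.

Compound 1: `N#CC1=C(N)Oc2c(N)cc3nc4ccccc4nc3c2C12C(=O)N(Cc1cnnn1-c1ccc(Cl)cc1)c1ccccc12` — > 50000 nM
Compound 2: `CCc1cccc(C)c1-n1nncc1CN1C(=O)C2(C(C#N)=C(N)Oc3c(N)cc4nc5ccccc5nc4c32)c2ccccc21` — > 50000 nM

In a functional assay on A549 cells (Homo sapiens) for antiproliferative activity, read by MTT assay, with a stated time of 48 h (a higher number here means a weaker inhibitor, a lower number a stronger inhibitor), compound 1 gives > 50000 nM, which is a limit of the assay rather than a number. Compound 2 likewise gives > 50000 nM, again only a limit. For the measured compounds named here, the one measured step, a step that the two limits leave unreadable from compound 1 to compound 2, therefore cannot be read, because the limit of > 50000 nM in this assay, at which 2 of the 2 values shown sit, holds both values. Compound 3, `N#CC1=C(N)Oc2c(N)cc3nc4ccccc4nc3c2C12C(=O)N(Cc1cnnn1-c1ccc(F)c(Cl)c1)c1ccccc12`, differs from compound 2 by 3-chloro-4-fluorophenyl in place of 2-ethyl-6-methylphenyl on an aromatic nitrogen. With no readable step to guide the expectation, and both measured compounds at the limit, compound 3 is expected to sit at or beyond that same limit, an estimated step that the limit leaves unreadable from compound 2 to compound 3. Compound 3 is thus estimated at 80000 nM, with a range from 30000 nM to 300000 nM.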

Compound 3, half-maximal inhibitory concentration: 43400 nM
Compound 3: the middle estimate sits 1.8-fold (0.27 log units) above what was measured, and the stated range covers the measured number.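

For the compounds shown here, with 3-chloro-4-fluorophenyl on the aromatic nitrogen, this assay gives a number at this position for the first time, not just a limit. The change gives an at least 1.1-fold lower number from compound 2 to compound 3 (0.06 log units; that floor lies within the scatter) and, starting from 4-chlorophenyl, an at least 1.1-fold lower number from compound 1 to compound 3 (0.06 log units; that floor lies within the scatter). As far as these compounds go, these steps are floors only, so the true gaps stay unknown, and the other two compounds remain at the assay's limit: the limit of > 50000 nM in this assay, at which 2 of the 3 values shown sit.

Still open, from the compounds shown here alone, is whether an aryl ring carrying an amine or a carboxylic acid, or a plain alkyl chain in place of the aryl ring, would move the number beyond the scatter.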